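This account rests on a few compounds, and the source may have more. Where it says the series, first, only, none or still open, it means among the compounds named here.

Measured in an ADME assay on Caco-2 cells (Homo sapiens) for permeability, read by LC-MS, in the apical to basolateral direction, with a stated time of 60 min, at pH 6.5; on this read-out higher numbers stand for higher permeability and lower numbers for lower permeability:
- compound 1 `O=C(NCc1cc(Cl)ccc1-n1cnnn1)[C@@H]1C[C@@H]2C[C@@H]2N1C(=O)[C@H](O)CC1CC1`: 3.6 10^-6 cm/s
- compound 2 `O=C(NCc1cc(Cl)ccc1-n1cnnn1)[C@@H]1C[C@H]2C[C@H]2N1C(=O)[C@H](O)CC1CC1`: 6.9 10^-6 cm/s
- compound 3 `COC(C)(C)[C@@H](O)C(=O)N1C[C@H]2C[C@H]2[C@H]1C(=O)NCc1cc(Cl)ccc1-n1cnnn1`: 3.5 10^-6 cm/s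

In this assay, compound 2 gives 6.9 10^-6 cm/s, which lies within the scatter of both compound 1 and compound 3. Compound 4 `CC(C)(C)C[C@@H](O)C(=O)N1[C@@H]2C[C@@H]2C[C@H]1C(=O)NCc1cc(Cl)ccc1-n1cnnn1` has tert-butyl in place of cyclopropyl on a saturated chain carbon, two bonds along the chain from a carbonyl carbon and an oxygen on a saturated carbon. Among the compounds with values here, the one measured step, a 1.9-fold higher number from compound 1 to compound 2 (0.28 log units; within the scatter), lies within the scatter and concerns (the fact that compounds 1 and 2 differ only in the configuration as drawn), so it does not test this swap. Within the data shown here, with no measured step to suggest a direction, none beyond the scatter is expected in this assay. The estimated 1.3-fold lower number from compound 2 to compound 4 (0.10 log units; within the scatter) therefore stays within the scatter. For compound 4 the expected value is 5.5 10^-6 cm/s, with an estimated range of 2.5 10^-6 cm/s to 11 10^-6 cm/s.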

Compound 4, apparent permeability: 24 10^-6 cm/s
Compound 4: middle estimate off by 4.4-fold (0.64 log units), on the low side; measured number outside the range, above it.
By their numbers in this assay, from the lowest: compounds 3, 1 and 2 (each within the scatter of the next); then compound 4.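

At this place on the chain, swapping the end group moves the read-out beyond the scatter in this assay: tert-butyl in place of cyclopropyl brings a 3.5-fold higher number from compound 2 to compound 4 (0.54 log units; beyond the scatter). Within the data shown here, the earlier step changed only the configuration as drawn, so this is the first sign that the group itself can matter on this read-out. Among these compounds, nothing measured so far accounts for the rise. This rests on a single pair of compounds. Going by these compounds, whether a smaller isopropyl, a longer chain or an amine at this place would give a similar number remains open.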